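Nitro in Place of Fluoro: Expecting Compound 4

A few compounds are considered here, and "the series" means these few. Any claim that something is new, unique, unknown or untested is made for them only; others in the source may bear on it.

compound 1 `COc1ccc(C(=O)/C=C/c2cc(OC)c(OC)c(OC)c2)c2c1C=CC(C)(C)O2`: 7650 nM
compound 2 `COc1ccc(C(=O)/C=C/c2ccc(F)cc2)c2c1C=CC(C)(C)O2`: > 10000 nM
compound 3 `COc1ccc(C(=O)/C=C/c2ccc3ccccc3c2)c2c1C=CC(C)(C)O2`: 5820 nM

Of the compounds shown here, three sharing one core have been tested in a functional assay on HCT-116 cells (Homo sapiens) for antiproliferative activity, read by MTT assay, with a stated time of 24 h; a higher number here means a weaker inhibitor, a lower number a stronger inhibitor. Compound 1 gives 7650 nM and compound 3 gives 5820 nM; these two values lie within the usual scatter of each other. For compound 2 the assay reports only a limit, > 10000 nM, not a number. This is the limit at which one of the three values sits (the limit of > 10000 nM in this assay, at which 1 of the 3 values shown sits).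

Compound 4 `COc1ccc(C(=O)/C=C/c2ccc([N+](=O)[O-])cc2)c2c1C=CC(C)(C)O2` has not yet been measured. It differs from compound 2 by nitro in place of fluoro on an aromatic carbon. For the measured compounds named here, no step between measured compounds exists, so the size and direction of this change are open. The expected step is an at least 1.2-fold lower number from compound 2 to compound 4 (0.09 log units; that floor lies within the scatter), a gain that may not exceed the scatter. Compound 4 is therefore estimated at 8000 nM, with a range from 3000 nM to 20000 nM.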

Compound 4, half-maximal inhibitory concentration: 8880 nM
Compound 4: middle estimate off by 1.1-fold (0.05 log units), on the low side, and the stated range covers the measured number.
By their numbers in this assay, from the lowest: compounds 3, 1 and 4 (each within the scatter of the next). At a limit, above all of these: compound 2.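

In this assay the swap from 4-fluorophenyl to 4-nitrophenyl gives an at least 1.1-fold lower number from compound 2 to compound 4 (0.05 log units; that floor lies within the scatter) as the first step read at this position. Compound 2 has only > 10000 nM as its value, a limit of the assay and not a number. As far as these compounds go, the step is therefore a floor, and its full size stays unknown, while nitro at this place yields a number that can be read.

From the compounds shown here alone, whether an amine or a carboxylic acid on this aromatic carbon would carry the number beyond the scatter stays open. One swap at one position also cannot show a trend.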